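Removing a Methyl: Expected Growth Inhibition for Compound 4

The source may hold more compounds than are shown below. What is called first, only, known or untested is meant among the compounds shown, and "the series" means these compounds.

Of the compounds shown here, three built on one shared core have been measured in a functional assay on BT-549 cells (Homo sapiens) for inhibition, read by sulforhodamine B assay, with a stated time of 48 h; a lower number here means a stronger inhibitor of growth, a higher number a weaker inhibitor of growth. Compound 2 `COc1cc(-c2nn(-c3cccc(NC(=O)Nc4cccc(C(F)(F)F)c4)c3)cc2-c2ccncc2)ccc1Cl` gives 3810 nM in this assay. Compound 1 `O=C(Nc1cccc(-n2cc(-c3ccncc3)c(-c3ccc(Cl)c(O)c3)n2)c1)Nc1cccc(C(F)(F)F)c1` carries the same core with one change, (hydrogen in place of methyl on an oxygen on an aromatic ring), and compound 1 gives 21400 nM; the step is a 5.6-fold higher number from compound 2 to compound 1 (0.75 log units; beyond the scatter). Compound 3 `COc1cc(-c2nn(-c3cccc(NC(=O)Nc4ccc(Cl)c(C(F)(F)F)c4)c3)cc2-c2ccncc2)ccc1Cl` differs from compound 2 elsewhere in the molecule, by chloro in place of hydrogen on an aromatic carbon; compound 3 gives 10200 nM, and the step is a 2.7-fold higher number from compound 2 to compound 3 (0.43 log units; beyond the scatter). Compound 4 `O=C(Nc1cccc(-n2cc(-c3ccncc3)c(-c3ccc(Cl)c(O)c3)n2)c1)Nc1ccc(Cl)c(C(F)(F)F)c1` has not yet been measured. It differs from compound 3 by hydrogen in place of methyl on an oxygen on an aromatic ring, and the place of this change reads exactly as the place of the change from compound 2 to compound 1, so the same change is made twice among these compounds. Because a 5.6-fold higher number from compound 2 to compound 1 (0.75 log units; beyond the scatter) was a modest weakening beyond the scatter, a step of comparable size is expected for compound 4, namely a 4.9-fold higher number from compound 3 to compound 4 (0.69 log units; beyond the scatter). This rests on a single earlier example, so the range is kept wide. Compound 4 is therefore estimated at 50000 nM, between 20000 nM and 100000 nM.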

Compound 4, concentration for total growth inhibition: 8070 nM
For compound 4 the middle estimate is 6.2-fold (0.79 log units) above the measured one, outside the stated range (below it).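

In this assay, the change from methoxy to hydroxy gives a 1.3-fold lower number from compound 3 to compound 4 (0.10 log units; within the scatter), so the clear weakening seen with this change on the core of compound 2 does not carry over to the core of compound 3: the same change on two cores in this assay, a 5.6-fold higher number (0.75 log units; beyond the scatter) from compound 2 to compound 1 and a 1.3-fold lower number (0.10 log units; within the scatter) from compound 3 to compound 4, 7.1-fold (0.85 log units) apart, beyond the scatter of two such steps. The chloro change also fails to carry over, as a 2.7-fold lower number from compound 1 to compound 4 (0.42 log units; beyond the scatter) runs opposite to the step it produced on the core of compound 2: the same change on two cores in this assay, a 2.7-fold higher number (0.43 log units; beyond the scatter) from compound 2 to compound 3 and a 2.7-fold lower number (0.42 log units; beyond the scatter) from compound 1 to compound 4, 7.1-fold (0.85 log units) apart, beyond the scatter of two such steps. Within these four compounds, the result of each change depends on whether the other is present, but with a single pair of steps for each change, this gives no general rule for other cores and does not reveal what lies behind the difference.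

The compounds shown leave open whether an ethoxy group or an amine in place of the methoxy would also behave differently on the two cores. They also leave open whether a bromo group in place of the added chloro would reverse direction in the same way.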